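The source may report more compounds than this note shows. Statements on the series, on what has been measured and on what is new or still open speak of the compounds shown alone.

Working notes on the series.

Of the compounds shown here, three have been read in a functional assay on RKO cells (Homo sapiens) for antiproliferative activity, read by MTT assay, with a stated time of 72 h; on this read-out lower numbers stand for stronger inhibition and higher numbers for weaker inhibition. Compound 1 `COc1cccc(/C=C2\CCC/C(=C\c3cc(OC)c(OC)c(OC)c3)C2=O)c1OC` gives 3600 nM. Compound 2 `COc1cc(/C=C2\CCC/C(=C\c3ccccc3Br)C2=O)cc(OC)c1OC` gives 2500 nM. Compound 3 `COc1cc(/C=C2\CCC/C(=C\c3ccccc3F)C2=O)cc(OC)c1OC` gives 1500 nM. Compound 3 thus stands with the lowest number of the three: the step of a 2.4-fold lower number from compound 1 to compound 3 (0.38 log units; beyond the scatter) is the only one beyond the scatter, while the step of a 1.7-fold lower number from compound 2 to compound 3 (0.22 log units; within the scatter) and the step of a 1.4-fold lower number from compound 1 to compound 2 (0.16 log units; within the scatter) both stay within it.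

The next compound, compound 4 `COc1cc(/C=C2\CCC/C(=C\c3cccc(O)c3)C2=O)cc(OC)c1OC`, differs from compound 3 in one place: 3-hydroxyphenyl in place of 2-fluorophenyl on a double-bonded chain carbon bound to a double-bonded ring carbon. Among the measured compounds shown here, the steps that bear on this change are the two that swap the aryl group on the same double-bonded chain carbon, namely from compound 1 to compound 3 and from compound 2 to compound 3, together with the swap from compound 1 to compound 2. All three of these stayed small, and only one cleared the scatter. For the measured compounds named here, nothing measured so far covers a hydroxyphenyl at this position, so the direction is open. On these grounds a small step is expected in this assay, most likely within the scatter, with no strong lean either way.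

The expected step from compound 3 to compound 4 is a 1.3-fold higher number from compound 3 to compound 4 (0.12 log units; within the scatter). Compound 4 is estimated at 2000 nM, within a range from 800 nM to 5000 nM.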

Compound 4, half-maximal inhibitory concentration: 6500 nM
Estimate against measurement, compound 4: 3.3-fold (0.51 log units) below; the whole stated range lies below it.
By their numbers in this assay, from the lowest: compounds 3, 2, 1 and 4 (each within the scatter of the next, the first and the last beyond it).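

In this assay, among the compounds shown here, the aryl group on a double-bonded chain carbon bound to a double-bonded ring carbon now gives steps beyond the scatter against both halogen-bearing compounds: 3-hydroxyphenyl in place of 2-fluorophenyl gives a 4.3-fold higher number from compound 3 to compound 4 (0.64 log units; beyond the scatter) and is the largest step so far, while 3-hydroxyphenyl in place of 2-bromophenyl gives a 2.6-fold higher number from compound 2 to compound 4 (0.41 log units; beyond the scatter) as the second result. Compound 1 goes against any simple split between halogen-bearing and other aryl groups, since 3-hydroxyphenyl in place of 2,3-dimethoxyphenyl gives only a 1.8-fold higher number from compound 1 to compound 4 (0.26 log units; within the scatter) and stays within the scatter. No measurement bearing on why the number moves with this change is at hand.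

The change from 2-fluorophenyl to 3-hydroxyphenyl alters both the substituent and its place on the ring, so the compounds shown do not separate the two, and 2-hydroxyphenyl and 3-fluorophenyl would be the direct pair to read against compound 3 and compound 4. Also open, going by these compounds, is whether the hydroxy group itself matters, which 3-methoxyphenyl, 3-aminophenyl and 3-carboxyphenyl at this place would test.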